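Fluoro and Trifluoromethyl Swaps Against Cell Toxicity

A few compounds are considered here, and "the series" means these few. Any claim that something is new, unique, unknown or untested is made for them only; others in the source may bear on it.

Compound 1 `O=S(=O)(c1ccccc1)n1c(-c2cn(-c3ccccc3)nc2-c2ccc(F)cc2)nc2ccccc21`: 96300 nM
Compound 2 `O=S(=O)(c1ccc(F)cc1)n1c(-c2cn(-c3ccccc3)nc2-c2ccc(F)cc2)nc2ccccc21`: 218000 nM
Compound 3 `O=S(=O)(c1ccc(C(F)(F)F)cc1)n1c(-c2cn(-c3ccccc3)nc2-c2ccc(F)cc2)nc2ccccc21`: 241000 nM

Three measured compounds share a core and differ only in one aromatic substituent. In an ADME assay on HEK-293T cells (Homo sapiens) for cytotoxicity, read by MTT assay, with a stated time of 24 h (on this read-out lower numbers stand for higher toxicity in this test and higher numbers for lower toxicity in this test), compound 1 gives 96300 nM, the lowest of the three numbers. The step of a 2.3-fold higher number from compound 1 to compound 2 (0.35 log units; beyond the scatter) and the step of a 2.5-fold higher number from compound 1 to compound 3 (0.40 log units; beyond the scatter) both lie beyond the scatter, whereas the step of a 1.1-fold higher number from compound 2 to compound 3 (0.04 log units; within the scatter) lies within it. Compound 2 and compound 3 are related by trifluoromethyl in place of fluoro on an aromatic carbon; compound 2 and compound 1 are related by hydrogen in place of fluoro on an aromatic carbon.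

Compound 4 `O=S(=O)(c1ccccc1)n1c(-c2cn(-c3ccccc3)nc2-c2ccc(C(F)(F)F)cc2)nc2ccccc21` has not yet been measured. It differs from compound 1 by trifluoromethyl in place of fluoro on an aromatic carbon, the same change that relates compound 2 to compound 3. Because that change gave only a 1.1-fold higher number from compound 2 to compound 3 (0.04 log units; within the scatter), compound 4 is expected to sit close to compound 1, with an estimated step of a 1.1-fold higher number from compound 1 to compound 4 (0.06 log units; within the scatter) in this assay. Compound 4 is therefore estimated at 110000 nM, between 50000 nM and 250000 nM.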

Compound 4, half-maximal cytotoxic concentration: 128000 nM
Compound 4: middle estimate off by 1.2-fold (0.07 log units), on the low side, and the stated range covers the measured number.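

In this assay, trifluoromethyl in place of fluoro gives a 1.3-fold higher number from compound 1 to compound 4 (0.12 log units; within the scatter). On neither core does this change produce a step beyond the scatter, and the two steps do not differ: the same change on two cores in this assay, a 1.1-fold higher number (0.04 log units; within the scatter) from compound 2 to compound 3 and a 1.3-fold higher number (0.12 log units; within the scatter) from compound 1 to compound 4, 1.2-fold (0.08 log units) apart, within the scatter of two such steps. This shows that a small step carried over between these two cores in this one cell test, but two pairs set no rule for the series and do not show how the change would behave on any other core.

The compounds shown leave open what an amine, a carboxylic acid or a methoxy group in place of fluoro would do to the number. They also leave open whether a longer chain there would give a step beyond the scatter.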